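Working notes on the step to compound 4

The compounds below may be only part of what the source reports. "The series", "measured", "known", "first", "only" and "open" are said of these compounds alone.

Compound 1 `CSc1ccc(C#Cc2ccc(C(=O)N3CCC[C@@H](CO)C3)cc2)cc1` carries a methylsulfanyl group on the outer aromatic ring. In a functional assay on TREX cells for negative allosteric modulation of metabotropic glutamate receptor 3 (Rattus norvegicus), read by calcium flux, with a stated time of 2.5 min (on this read-out lower numbers stand for stronger inhibition and higher numbers for weaker inhibition), compound 1 returns only > 10000 nM, which is a limit of the assay and not a number. Compound 2 `CCOc1ccc(C#Cc2ccc(C(=O)N3CCC[C@@H](CO)C3)cc2)cc1` has ethoxy in that place, and in this assay compound 2 likewise returns only the limit > 10000 nM. Compound 3 `O=C(c1ccc(C#Cc2ccc(O)cc2)cc1)N1CCC[C@@H](CO)C1` bears a hydroxy group there; in this assay compound 3 gives the limit > 10000 nM. The steps a step that the two limits leave unreadable from compound 1 to compound 2, a step that the two limits leave unreadable from compound 1 to compound 3 and a step that the two limits leave unreadable from compound 2 to compound 3 are all unreadable, since every compound involved sits at the limit of > 10000 nM in this assay, at which 3 of the 3 values shown sit. Compound 3 thus stands at the limit, as do both of its neighbours in the series, and no ranking among the three is possible.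

Compound 4 `COc1ccc(C#Cc2ccc(C(=O)N3CCC[C@@H](CO)C3)cc2)cn1` has not been measured. The change is 6-methoxypyridin-3-yl in place of 4-hydroxyphenyl on a triple-bonded carbon. Among the measured compounds shown here, none of the measured steps can be read, so neither size nor direction can be taken from them; all they show is that methylsulfanyl, ethoxy and hydroxy on that ring give no measurable inhibition. Compound 4 is therefore estimated at 8000 nM, with an expected range from 2000 nM to 30000 nM, and most probably it will again return only a limit. The expected step is an at least 1.2-fold lower number from compound 3 to compound 4 (0.09 log units; that floor lies within the scatter).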

Compound 4, half-maximal inhibitory concentration: > 10000 nM
Compound 4: a limit, no number (the forecaster's own chance of this, stated with the estimate: 70%); at least 1.2-fold (0.09 log units) between middle value and limit.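

In this assay compound 4 returns > 10000 nM, which is a limit of the assay and not a number. Its steps from compound 1, compound 2 and compound 3 therefore cannot be read: the limit of > 10000 nM in this assay, at which 4 of the 4 values shown sit. The compounds shown leave open whether any group on that triple-bonded carbon gives measurable inhibition, and how these four rank among themselves.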